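The compounds below may be only part of what the source reports. "The series", "measured", "known", "first", "only" and "open" are said of these compounds alone.

Compound 1, `O=C1CSc2cc(OCC3CCCCC3)ccc2N1`, and compound 2, `O=C1CSc2cc(OCc3ccc(Cl)cc3)ccc2N1`, share a common core and differ only in the group attached to it. In an assay on isolated protein for inhibition of Amine oxidase [flavin-containing] B (Homo sapiens), read by fluorescence and spectrophotometry, with a stated time of 20 min (a lower number here means a stronger inhibitor, a higher number a weaker inhibitor), compound 1 gives 24 nM, while compound 2 gives 2.7 nM. Among the two numbers recorded, compound 2 stands lowest, with compound 1 the nearest to it at a gap that lies beyond the usual scatter of this measurement. Compound 3, `Cc1ccc(COc2ccc3c(c2)SCC(=O)N3)cc1`, has not yet been measured; it differs from compound 2 in a single place: methyl in place of chloro on an aromatic carbon. Going by the values given here, no pair of measured compounds that differ in one position is available, so there is no measured step to lean on, and the two values in hand speak only of the two attached groups taken as wholes. The expectation is that the step from compound 2 to compound 3 in this assay will be small, a 1.9-fold higher number from compound 2 to compound 3 (0.27 log units; within the scatter), toward a somewhat higher number, and may not exceed the scatter. Compound 3 is therefore estimated at 5 nM in this assay, within a range from 1.5 nM to 15 nM.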

Compound 3, half-maximal inhibitory concentration: 8.2 nM
Compound 3: the middle estimate sits 1.6-fold (0.21 log units) below what was measured, and the stated range covers the measured number.
By their numbers in this assay, from the lowest: compound 2; then compound 3; then compound 1.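

In this assay, the change from chloro to methyl on an aromatic carbon, para to a large group, supplies the only single-place comparison among these compounds: a 3.0-fold higher number from compound 2 to compound 3 (0.48 log units; beyond the scatter). Compound 1 and compound 2 differ in the attached group as a whole, whereas this step shows that exchanging one heavy atom for another at this position, with no hydrogen-bond donor, hydrogen-bond acceptor or net charge entering or leaving, can move the number modestly but beyond the usual scatter, with chloro giving the lower number in this pair. The compounds offer no measurement that accounts for this difference between chloro and methyl.

Going by these compounds, what remains open is whether the order seen here extends to other groups at this carbon, such as fluoro, methoxy or an amine, and whether any of them would match or improve on compound 2 at 2.7 nM. Also open, on these data alone, is how a carboxylic acid or a longer chain would fare there, and whether chloro and methyl would differ similarly on another carbon of the same ring.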